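The source may report more compounds than this note shows. Statements on the series, on what has been measured and on what is new or still open speak of the compounds shown alone.

Three compounds share one sugar-like core carrying a methoxy group and a cyclohexyloxy-phenyl ether, differing in the aryl ether on the saturated carbon. In a functional assay on MDA-MB-231 cells (Homo sapiens) for cytotoxicity, read by MTT assay, with a stated time of 48 h, tested at 20 uM (a higher number here means more inhibition at the concentration tested (going by the name of the read-out), a lower number less inhibition), compound 1 `CO[C@H]1O[C@H](COc2cccc3c2CCCC3)[C@@H](O)[C@H](O)[C@H]1Oc1ccc(OC2CCCCC2)cc1` gives -8%, compound 2 `CO[C@H]1O[C@H](COc2ccc3c(c2)CCCC3)[C@@H](O)[C@H](O)[C@H]1Oc1ccc(OC2CCCCC2)cc1` gives 24%, and compound 3 `CO[C@@H]1O[C@H](COc2ccccc2)[C@@H](O)[C@H](O)[C@H]1Oc1ccc(OC2CCCCC2)cc1` gives -9%. Within the data shown here, compound 3 therefore sits at the low end of the three numbers, within the scatter of compound 1 and well under compound 2; the one measured step, a number 32 percentage points higher from compound 1 to compound 2 (beyond the scatter), moves an aryl group between two positions.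

Compound 4 `CO[C@H]1O[C@H](COc2ccccc2)[C@@H](O)[C@H](O)[C@H]1Oc1ccc(OC2CCCCC2)cc1` differs from compound 3 only in this: the two compounds have the same atoms and bonds and differ only in configuration as drawn: 1 of 5 stereo elements differ; a stereocentre at a saturated ring carbon is drawn R in compound 3 and S in compound 4. No measured step here changes a stereocentre, so nothing shown speaks for a shift, and the expected step of a number 4 percentage points higher from compound 3 to compound 4 (within the scatter) is none beyond the scatter; compound 4 is estimated at -5%, between -25% and 15%.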

Compound 4, a percentage reported as inhibition, at one concentration (the size of the read-out at that concentration, not a potency): -11%
For compound 4 the middle estimate is 6 percentage points above the measured one, within the range that was stated.
By their numbers in this assay, from the lowest: compounds 4, 3 and 1 (each within the scatter of the next); then compound 2.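

Drawing this ring carbon the other way shows no shift beyond the scatter in this assay, with a number 2 percentage points lower from compound 3 to compound 4 (within the scatter), and the pair isolates that single feature: the fact that compounds 3 and 4 differ only in the configuration as drawn. Phenyl in place of 1,2,3,4-tetrahydronaphthalen-6-yl gives a number 35 percentage points lower from compound 2 to compound 4 (beyond the scatter), whereas phenyl in place of 1,2,3,4-tetrahydronaphthalen-5-yl gives a number 3 percentage points lower from compound 1 to compound 4 (within the scatter), so among these aryl groups only the 6-yl group stands apart.

Going by these compounds, whether this stereocentre matters when 1,2,3,4-tetrahydronaphthalen-6-yl is present remains open. So does what an amine or a carboxylic acid on the phenyl ring would do.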